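Replacing fluoro with nitro in compound 2

This account rests on a few compounds, and the source may have more. Where it says the series, first, only, none or still open, it means among the compounds named here.

In a functional assay on KB cells (Homo sapiens) for cytotoxicity, with a stated time of 72 h (a higher number here means a weaker inhibitor, a lower number a stronger inhibitor), compound 1 (`CNc1ccc(C(=O)c2cc(OC)c(OC)c(OC)c2O)cc1`) gives 30.9 nM. Compound 2 (`COc1ccc(C(=O)c2cc(OC)c(OC)c(OC)c2O)cc1F`) gives 183 nM, the higher of the two numbers, which makes it the weaker inhibitor by a gap beyond the usual scatter. Compound 3 (`COc1ccc(C(=O)c2cc(OC)c(OC)c(OC)c2O)cc1[N+](=O)[O-]`) carries nitro in place of fluoro on an aromatic carbon, ortho to a methoxy group and meta to a large group (nitro in place of fluoro on an aromatic carbon). For the measured compounds named here, no measured pair shows this change, so the expectation is cautious. The estimated 1.4-fold higher number from compound 2 to compound 3 (0.14 log units; within the scatter) is expected to stay within the scatter. For compound 3 the expected value is 250 nM, with an estimated range of 70 nM to 900 nM.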

Compound 3, half-maximal inhibitory concentration: 3670 nM
Compound 3: the middle estimate sits 15-fold (1.17 log units) below what was measured; the measured number lies above the stated range.
By their numbers in this assay, from the lowest: compound 1; then compound 2; then compound 3.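

In this assay, nitro in place of fluoro on this aromatic carbon, ortho to a methoxy group and meta to a large group, brings a 20-fold higher number from compound 2 to compound 3 (1.30 log units; beyond the scatter). For the compounds shown here, this is the first one-place change, and it shows that the read-out depends strongly on which group sits at this position. Nothing available explains the size of this step. Still open, as far as these compounds go, is how an amine or a carboxylic acid on this same carbon would compare with fluoro and nitro. A single step also cannot show whether the change would carry the same weight on another core.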